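The compounds below may be only part of what the source reports. "The series", "measured", "known", "first", "only" and "open" are said of these compounds alone.

Measured in an ADME assay on Huh-5-2 cells (Homo sapiens) for cytotoxicity, read by WST assay, with a stated time of 3 days; on this read-out higher numbers stand for lower toxicity in this test and lower numbers for higher toxicity in this test:
Compound 1, `Cc1ccccc1COc1cc(O)c2c(=O)c(O)c(-c3ccccc3)oc2c1`, gives 17000 nM.
Compound 3, `Cc1ccc(COc2cc(O)c3c(=O)c(O)c(-c4ccccc4)oc3c2)cc1`, gives 88000 nM.
Compound 2, `COc1ccccc1COc1cc(O)c2c(=O)c(O)c(-c3ccccc3)oc2c1`, gives only a limit of the assay, > 100000 nM.

The change from compound 1 to compound 2 is methoxy in place of methyl on an aromatic carbon, and it produced an at least 5.8-fold higher number from compound 1 to compound 2 (0.76 log units; beyond the scatter); this step is known only as a floor owing to the limit of > 100000 nM in this assay, at which 1 of the 3 values shown sits. Compound 4, `COc1ccc(COc2cc(O)c3c(=O)c(O)c(-c4ccccc4)oc3c2)cc1`, is not yet measured and differs from compound 3 by methoxy in place of methyl on an aromatic carbon. The two cores differ by 4-methylphenyl in place of 2-methylphenyl on a saturated chain carbon bound to an oxygen on an aromatic ring, a change that gave a 5.2-fold higher number from compound 1 to compound 3 (0.71 log units; beyond the scatter). The place reads ortho to a large group in one pair and para to a large group in the other. The change is the same kind of change, not the same. Resting on an at least 5.8-fold higher number from compound 1 to compound 2 (0.76 log units; beyond the scatter), compound 4 is expected to show a 2.0-fold higher number from compound 3 to compound 4 (0.31 log units; beyond the scatter). Compound 4 is estimated at 180000 nM, between 60000 nM and 500000 nM, with a limit rather than a number quite likely.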

Compound 4, half-maximal cytotoxic concentration: > 100000 nM
Compound 4 was reported as a limit (the forecaster's own chance of this, stated with the estimate: 65%); the middle value is on the limit's open side.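

In this assay, the step on the core of compound 3 is an at least 1.1-fold higher number from compound 3 to compound 4 (0.05 log units; that floor lies within the scatter), and the wider change on the side chain gives an at least 5.8-fold higher number from compound 1 to compound 4 (0.76 log units; beyond the scatter); the step joining compound 2 and compound 4 cannot be read. These results show neither that methoxy in place of methyl carries from one core to the other at the same size nor that its size differs: the same change on two cores in this assay, an at least 5.8-fold higher number (0.76 log units; beyond the scatter) from compound 1 to compound 2 and an at least 1.1-fold higher number (0.05 log units; that floor lies within the scatter) from compound 3 to compound 4; the limit leaves it open whether they differ For compound 2 and compound 4, only limits are reported, not numbers: the limit of > 100000 nM in this assay, at which 2 of the 4 values shown sit.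

The compounds shown leave open how the read-out would respond to an amine or a carboxylic acid in place of methyl on this aromatic ring. They also leave open how a longer chain in place of methoxy would read.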